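Adding Trifluoromethyl to a Weak Chemokine Receptor Binder

This account rests on a few compounds, and the source may have more. Where it says the series, first, only, none or still open, it means among the compounds named here.

Measured compounds:
compound 1 `CN(CC1=CC[C@H]2C[C@@H]1C2(C)C)Cc1ccc(Br)cc1`: 3160 nM
compound 2 `CN(CC1=CC[C@H]2C[C@@H]1C2(C)C)Cc1ccc(-c2ccccc2)cc1`: 3160 nM

In an assay on HEK293 cells for displacement of a labelled ligand from C-X-C chemokine receptor type 3 (Homo sapiens) (a higher number here means a weaker inhibitor, a lower number a stronger inhibitor), compound 1 gives 3160 nM, and compound 2 gives 3160 nM. Going by the values given here, the single measured step, no change at the digits printed from compound 1 to compound 2 (within the scatter), shows that swapping one end group for another left the number where it was. Compound 2 therefore stands level with compound 1 within the scatter; neither can be called the stronger binder.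

Compound 3 `CN(CC1=CC[C@H]2C[C@@H]1C2(C)C)Cc1ccc(-c2cccc(C(F)(F)F)c2)cc1` is the next step from compound 2. The change is trifluoromethyl in place of hydrogen on an aromatic carbon. Among the compounds with values here, no measured step touches this kind of change, so the only guidance is that the one step on record, no change at the digits printed from compound 1 to compound 2 (within the scatter), changed nothing. On that basis the expected step of a 1.4-fold lower number from compound 2 to compound 3 (0.16 log units; within the scatter) is small, and may not exceed the scatter at all. Compound 3 is thus estimated at 2200 nM, with a range from 600 nM to 8000 nM.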

Compound 3, inhibition constant: > 316 nM
Compound 3: only a limit was reported; the forecaster's own chance of this, stated with the estimate: 10%; the middle value does not contradict the limit.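

In this assay compound 3 gives > 316 nM, which is a limit and not a number, so the step to it from compound 2 cannot be read. Going by these compounds, whether trifluoromethyl in place of hydrogen strengthens, weakens or leaves unchanged the binding of compound 2 stays open.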